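The source may hold more compounds than are shown below. What is called first, only, known or untested is meant among the compounds shown, and "the series" means these compounds.

Measured compounds in an ADME assay on CCRF-CEM cells (Homo sapiens) for cytotoxicity, with a stated time of 72 h; on this read-out higher numbers stand for weaker inhibition and lower numbers for stronger inhibition:
- Compound 1 `O=Cc1c(-c2ccc(F)cc2)nc2sc(Cc3ccc(Cl)cc3)nn12` gives 17000 nM
- Compound 2 `COc1ccc(-c2nc3sc(Cc4ccc(Cl)cc4)nn3c2C=O)cc1` gives 3800 nM

Compound 2 gives the lowest of the two numbers in this assay; its nearest neighbour is compound 1, and the step of a 4.5-fold lower number from compound 1 to compound 2 (0.65 log units; beyond the scatter) is beyond the scatter. The step now followed leads from compound 2 to compound 3 `O=Cc1c(-c2ccccc2)nc2sc(Cc3ccc(Cl)cc3)nn12`: hydrogen in place of methoxy on an aromatic carbon. Among the compounds with values here, only one measured step bears on it, a 4.5-fold lower number from compound 1 to compound 2 (0.65 log units; beyond the scatter), in which methoxy replacing fluoro on the same aromatic carbon gave a modestly lower number. Compound 3 carries neither group there, so the data give no direct reading for hydrogen at that place. The expectation is that losing the methoxy moves the number back toward compound 1, but with wide uncertainty, since nothing shows whether hydrogen behaves like fluoro. Compound 3 is therefore expected at 10000 nM, with a range of 3000 nM to 30000 nM, an estimated step of a 2.6-fold higher number from compound 2 to compound 3 (0.42 log units; beyond the scatter).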

Compound 3, half-maximal inhibitory concentration: 22000 nM
The estimate for compound 3 lay 2.2-fold (0.34 log units) below the measured number; the measured number falls inside the stated range.
By their numbers in this assay, from the lowest: compound 2; then compounds 1 and 3 (each within the scatter of the next).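

In this assay, hydrogen in place of methoxy gives a 5.8-fold higher number from compound 2 to compound 3 (0.76 log units; beyond the scatter) and so shows that the lower number of compound 2 goes with the methoxy on this aromatic carbon, para to a large group. Hydrogen in place of fluoro gives a 1.3-fold higher number from compound 1 to compound 3 (0.11 log units; within the scatter) and lies within the scatter, so fluoro and hydrogen cannot be told apart at this place, and among these three compounds only methoxy sets its compound apart. Nothing available gives a reason for this difference.

Going by these compounds, whether the lower number is particular to methoxy stays open, as a hydroxyl, an ethoxy or an amine on the same carbon could show. The compounds shown also leave open whether the methoxy step would hold with a carboxylic acid in place of the aldehyde on the shared core.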